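Shorter nitrooxy chain on the ascorbate core

The source may hold more compounds than are shown below. What is called first, only, known or untested is meant among the compounds shown, and "the series" means these compounds.

Compound 1 `O=C1OC(C(O)CO)C(OCCCCCCO[N+](=O)[O-])=C1O` is the starting point of this comparison. In a physicochemical assay for lipophilicity, using the shake flask method, with a stated time of 4 h, at pH 1.0 (on this read-out higher numbers stand for higher lipophilicity and lower numbers for lower lipophilicity), compound 1 gives 0.86, the highest of the three numbers measured. Compound 2 `O=C1OC(C(O)CO)C(O)=C1OCCCCCCO[N+](=O)[O-]` shares every atom with compound 1, joined differently; how the two cores differ is not broken down here. In this assay compound 2 gives 0.84, which lies within the scatter of compound 1, so no order between the two is claimed. Compound 3 `O=C1OC(C(O)CO)C(O)=C1OCCCO[N+](=O)[O-]` is obtained from compound 2 by one change, (nitrooxy in place of 3-(nitrooxy)propyl on a saturated chain carbon, three bonds along the chain from an oxygen on an unsaturated carbon). In this assay compound 3 gives -0.26. That change produced a number 1.10 log units lower from compound 2 to compound 3 (beyond the scatter).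

Compound 4 `O=C1OC(C(O)CO)C(OCCCO[N+](=O)[O-])=C1O` has not yet been measured in this assay. It is obtained from compound 1 by the same change, (nitrooxy in place of 3-(nitrooxy)propyl on a saturated chain carbon, three bonds along the chain from an oxygen on an unsaturated carbon), at the same place in the same words. The step from compound 2 to compound 3 is the only measured example of it among these compounds, so the expectation for compound 4 rests on that single step and on the value of compound 1, 0.86. Because the measured change gave a number 1.10 log units lower from compound 2 to compound 3 (beyond the scatter), a step of closely similar size is expected here, a number 1.10 log units lower from compound 1 to compound 4 (beyond the scatter). On that basis compound 4 is estimated at -0.24 in this assay, with an expected range from -0.6 to 0.1.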

Compound 4, distribution coefficient: -0.48
For compound 4 the middle estimate is 0.24 log units above the measured one, and the stated range covers the measured number.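

In this assay the replacement of 3-(nitrooxy)propyl by nitrooxy gave a number 1.34 log units lower from compound 1 to compound 4 (beyond the scatter) and also a number 1.10 log units lower from compound 2 to compound 3 (beyond the scatter), so the change carried from one core to the other in direction, and on both cores the step is large. Among the compounds shown here, this is only two pairs, each with a single measurement at one pH, so it supports the direction for these four compounds but does not show that the step has a fixed size on any core, nor that it would hold on a core outside this series. Nothing available here bears on what lies behind the fall in the number on either core, and none can be assigned to the chain or to the way the cores differ.

The compounds shown leave open how the numbers run across chain lengths, since they offer only the two chains, and a longer chain than that of compound 1 could continue the trend or depart from it. They also leave open whether the same replacement would give a step of this kind on a core carrying an amine or a carboxylic acid.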